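Compound 4: fluorobenzyl for fluorophenoxy on the chain carbon

A few compounds are considered here, and "the series" means these few. Any claim that something is new, unique, unknown or untested is made for them only; others in the source may bear on it.

Working notes on the series. Compound 1 `O=C(O)CC/C=C\CC1COC(c2cccnc2)OC1c1cccnc1` gives 220 nM in an assay for inhibition of Thromboxane-A synthase (Homo sapiens), using microsomes; a lower number here means a stronger inhibitor, a higher number a weaker inhibitor. Going by the values given here, compound 2 `O=C(O)CC/C=C\CC1COC(c2ccc3ccccc3c2)OC1c1cccnc1` gives 50 nM in this assay; the step of a 4.4-fold lower number from compound 1 to compound 2 (0.64 log units; beyond the scatter) is the only single-point change measured so far. Compound 3 `CC(C)(Oc1ccc(F)cc1)C1OCC(C/C=C\CCC(=O)O)C(c2cccnc2)O1` gives 51 nM in this assay, the second highest of the three numbers; against compound 2 the gap is within the scatter, while compound 1 lies beyond it on the higher side.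

Compound 4 `CC(C)(Cc1ccc(F)cc1)C1OCC(C/C=C\CCC(=O)O)C(c2cccnc2)O1` differs from compound 3 in one place: 4-fluorobenzyl in place of 4-fluorophenoxy on a saturated chain carbon bound to two saturated chain carbons and a saturated ring carbon. Among the compounds with values here, the one measured step concerns the saturated ring carbon of the shared core and a swap of aromatic rings there; it carries no information on the saturated chain carbon, so no measured pair bears on the present change. Without precedent in this series, the expectation for compound 4 is no step beyond the scatter in this assay, and the expected step of a 1.0-fold lower number from compound 3 to compound 4 (0.01 log units; within the scatter) is set accordingly near zero. Compound 4 is estimated at 50 nM, with a range from 20 nM to 130 nM.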

Compound 4, half-maximal inhibitory concentration: 45 nM
Compound 4: middle estimate off by 1.1-fold (0.05 log units), on the high side, within the range that was stated.
By their numbers in this assay, from the lowest: compounds 4, 2 and 3 (each within the scatter of the next); then compound 1.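

Going by these compounds alone, the step in this assay is a 1.1-fold lower number from compound 3 to compound 4 (0.05 log units; within the scatter), the first measured change on this saturated chain carbon. 4-Fluorobenzyl carries no hydrogen-bond acceptor where 4-fluorophenoxy carries one, yet the step stays within the scatter, so in this pair the acceptor of 4-fluorophenoxy is not needed to keep the number at this level. No measurement on hand accounts for the two groups reading alike.

From the compounds shown here alone, whether this position responds to any group at all remains open, as both groups compared here are fluorinated aromatic groups of equal heavy-atom count; a plain benzyl, an amine or a longer alkyl chain would test this. Also open, going by these compounds, is whether the fluorine itself matters, which a comparison with an unsubstituted phenoxy would address.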